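The compounds below may be only part of what the source reports. "The series", "measured", "known", "first", "only" and "open" are said of these compounds alone.

Series notes. Compound 1 `Oc1ccc(O)c(-c2cc(-c3ccc(Cl)cc3)nn2-c2ccccc2)c1` gives 8860 nM in a functional assay on cells (Cancer cell lines, Homo sapiens) for cytotoxicity, read by sulforhodamine B assay, with a stated time of 48 h; on this read-out higher numbers stand for weaker inhibition of growth and lower numbers for stronger inhibition of growth. Compound 3 `O=C1C=CC(=O)C(c2cc(-c3ccc(Cl)cc3)nn2-c2ccccc2)=C1` gives 55600 nM in this assay. The change from compound 1 to compound 3 is a group of 8 heavy atoms (6 carbon, 2 oxygen; one six-membered non-aromatic ring of carbon only) in place of a group of 8 heavy atoms (6 carbon, 2 oxygen; one six-membered aromatic ring of carbon only), on an aromatic carbon and the step it made is a 6.3-fold higher number from compound 1 to compound 3 (0.80 log units; beyond the scatter). Compound 2 `CC(=O)NS(=O)(=O)c1ccc(-n2nc(-c3ccccc3)cc2-c2cc(O)ccc2O)cc1` gives 78100 nM in this assay; the difference between the core of compound 2 and the core of compound 1 is not broken down here. Compound 4 `CC(=O)NS(=O)(=O)c1ccc(-n2nc(-c3ccccc3)cc2C2=CC(=O)C=CC2=O)cc1` is not yet measured. It differs from compound 2 by a group of 8 heavy atoms (6 carbon, 2 oxygen; one six-membered non-aromatic ring of carbon only) in place of a group of 8 heavy atoms (6 carbon, 2 oxygen; one six-membered aromatic ring of carbon only), on an aromatic carbon, the same kind of change as from compound 1 to compound 3, though the surroundings of the place differ: in compound 1 the place is next to the ring atom that bears a phenyl group and two ring bonds from the ring atom that bears a 4-chlorophenyl group, whereas in compound 2 it is next to the ring atom that bears a large group and two ring bonds from the ring atom that bears a phenyl group. Only one measured example of this change exists among these compounds, so any expectation rests on it alone. Compound 4 is expected to show a step of a 3.8-fold higher number from compound 2 to compound 4 (0.58 log units; beyond the scatter) in this assay, in the same direction and of roughly the same size as a 6.3-fold higher number from compound 1 to compound 3 (0.80 log units; beyond the scatter). Because compound 2 already gives 78100 nM in this assay, compound 4 is expected to stand at a still higher number, that is, at still weaker inhibition of growth. Compound 4 is accordingly estimated at 300000 nM, with a plausible range from 80000 nM to 1000000 nM.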

Compound 4, concentration for 50% growth inhibition: 90000 nM
Compound 4: the middle estimate sits 3.3-fold (0.52 log units) above what was measured; measured number inside the range.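

Notes on the change. In this assay, putting the non-aromatic ring group in place of 2,5-dihydroxyphenyl on the core of compound 2 gives a 1.2-fold higher number from compound 2 to compound 4 (0.06 log units; within the scatter), so on this core the change has no effect that can be read. The change therefore does not carry over in size from one core to the other, and the step on the core of compound 1 cannot be used as a general value for the series: the same change on two cores in this assay, a 6.3-fold higher number (0.80 log units; beyond the scatter) from compound 1 to compound 3 and a 1.2-fold higher number (0.06 log units; within the scatter) from compound 2 to compound 4, 5.4-fold (0.74 log units) apart, beyond the scatter of two such steps The two cores differ in more than one place, so these two steps do not show which difference goes with the gap, and with a single pair per core they give no rule for any further core.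

The compounds shown leave open whether the gap follows the 4-chlorophenyl group or the large group, as no pair shown here varies one of these alone. Also open, going by these compounds, is how the same change behaves on a core with a carboxylic acid or an amine in place of the large group, and how a methoxy group on the phenyl ring in place of the hydroxyl groups of 2,5-dihydroxyphenyl compares with either group.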